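Methoxy to hydroxy on the pyrazole aryl arm

This account rests on a few compounds, and the source may have more. Where it says the series, first, only, none or still open, it means among the compounds named here.

Two members of this series have been measured in a functional assay on U-251 cells (Homo sapiens) for inhibition, read by sulforhodamine B assay, with a stated time of 48 h; on this read-out higher numbers stand for weaker inhibition of growth and lower numbers for stronger inhibition of growth. Compound 1 `O=C(Nc1cccc(-n2cc(-c3ccncc3)c(-c3ccc(Cl)c(O)c3)n2)c1)Nc1cccc(C(F)(F)F)c1` gives 7650 nM. Compound 2 `COc1cc(-c2nn(-c3cccc(NC(=O)Nc4cc(C(F)(F)F)cc(C(F)(F)F)c4)c3)cc2-c2ccncc2)ccc1Cl` gives 1370 nM, the lower of the two numbers; compound 1 stands beyond the scatter above it. Compound 1 and compound 2 differ in more than one place, so nothing is read from that pair about any single change.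

Compound 3 `O=C(Nc1cccc(-n2cc(-c3ccncc3)c(-c3ccc(Cl)c(O)c3)n2)c1)Nc1cc(C(F)(F)F)cc(C(F)(F)F)c1` is not yet measured. Relative to compound 2 the change is hydrogen in place of methyl on an oxygen on an aromatic ring. Going by the values given here, no measured pair isolates this change. Compound 1 carries the same hydroxy group and sits at the higher number, but with a different trifluoromethyl count, so no direction is fixed from it. A step of modest size, or none beyond the scatter, is expected; for the step from compound 2 to compound 3 the estimate is a 1.6-fold higher number from compound 2 to compound 3 (0.21 log units; within the scatter). For compound 3 the value expected in this assay is 2200 nM, with a range from 700 nM to 7000 nM.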

Compound 3, concentration for total growth inhibition: 1170 nM
The estimate for compound 3 lay 1.9-fold (0.27 log units) above the measured number, within the range that was stated.
By their numbers in this assay, from the lowest: compounds 3 and 2 (each within the scatter of the next); then compound 1.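

In this assay, going by these compounds alone, methoxy to hydroxy on the aromatic ring, isolated here for the first time, gives a 1.2-fold lower number from compound 2 to compound 3 (0.07 log units; within the scatter) and so does not separate the two groups at this position. Trifluoromethyl in place of hydrogen on an aromatic carbon, with the hydroxy group held constant, gives a 6.5-fold lower number from compound 1 to compound 3 (0.82 log units; beyond the scatter) and is the only single change shown that lies beyond the scatter. No measured property or other supporting data bears on either step.

From the compounds shown here alone, whether methoxy to hydroxy reads the same with a single trifluoromethyl group remains open. Also open, going by these compounds, is how an amine or an ethoxy group would read in the same place on the aromatic ring in this assay and whether either would separate from hydroxy and methoxy.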